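A few compounds are considered here, and "the series" means these few. Any claim that something is new, unique, unknown or untested is made for them only; others in the source may bear on it.

The measured compounds, each with its result:

Compound 1 `CC(C)n1ncc2c(C(=O)NCc3cn(-c4cccc(Br)c4)nn3)cccc21` gives > 40000 nM in a functional assay on MCF7 cells (Homo sapiens) for inhibition, read by MTT assay, with a stated time of 72 h (on this read-out lower numbers stand for stronger inhibition and higher numbers for weaker inhibition), which is a limit of the assay and not a number. Compound 2 `COc1ccc(-n2cc(CNC(=O)c3cccc4c3cnn4C(C)C)nn2)cc1` gives > 40000 nM, again a limit. Compound 3 `CC(C)n1ncc2c(C(=O)NCc3cn(Cc4ccc(C#N)cc4)nn3)cccc21` gives > 40000 nM, also a limit.

Compound 1 therefore stands nowhere readable on the scale: its value is only a limit, and the same holds for the two other values shown, as the limit of > 40000 nM in this assay, at which 3 of the 3 values shown sit, records.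

Compound 4 `COc1ccc(Cn2cc(CNC(=O)c3cccc4c3cnn4C(C)C)nn2)cc1` is the unmeasured compound. It differs from compound 1 in one place: 4-methoxybenzyl in place of 3-bromophenyl on an aromatic nitrogen.

Among the compounds with values here, three measured steps touch the same aromatic nitrogen. The step that the two limits leave unreadable from compound 1 to compound 2 cannot be read because both ends are limits. The step that the two limits leave unreadable from compound 1 to compound 3 and the step that the two limits leave unreadable from compound 2 to compound 3 are unreadable for the same reason. None of them shows a direction or a size, so the expected step from compound 1 to compound 4 cannot be given a direction either, and the most likely outcome is a further limit.

Compound 4 is estimated at 60000 nM, with a range from 20000 nM to 200000 nM. The step that the limit leaves unreadable from compound 1 to compound 4 is the expected step, read only against a limit.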

Compound 4, half-maximal inhibitory concentration: > 40000 nM
Compound 4: only a limit was reported; the forecaster's own chance of this, stated with the estimate: 85%; the middle value does not contradict the limit.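

No step between compound 4 and compound 1, compound 2 or compound 3 can be read, because all four compounds give only a limit of the assay and not a number: the limit of > 40000 nM in this assay, at which 4 of the 4 values shown sit.

The compounds shown leave open how strongly any of them inhibits these cells, and which group on the aromatic nitrogen, if any, would give a readable value.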